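Swapping Ethyl for Oxan-4-yl and Cell Tolerance

The source may report more compounds than this note shows. Statements on the series, on what has been measured and on what is new or still open speak of the compounds shown alone.

Compound 1 `CCC(=O)Nc1ncc(-c2ccc(OC)cc2)n1C` has been tested in a toxicity assay on THP-1 cells (Homo sapiens) for inhibition; a lower number here means that less compound is tolerated, a higher number that more compound is tolerated. In this assay compound 1 gives > 100000 nM, which is a limit of the assay rather than a number. Compound 2 `COc1ccc(-c2ccc(NC(=O)c3ccc(F)cc3)nc2)cc1` likewise gives > 100000 nM, a limit. Compound 3 `COc1ccc(-c2cccc(NC(=O)c3ccc(F)cc3)n2)cc1` also gives > 100000 nM, again a limit. Compound 1 therefore stands where every measured value stands, because of the limit of > 100000 nM in this assay, at which 3 of the 3 values shown sit. Compound 4 `COc1ccc(-c2cnc(NC(=O)C3CCOCC3)n2C)cc1` has not yet been measured. It differs from compound 1 in one place: oxan-4-yl in place of ethyl on a carbonyl carbon. For the measured compounds named here, no step between measured compounds is available to gauge this change, and the three limits show only that no tolerated concentration has yet been reached. The expected step of a number no higher from compound 1 to compound 4 (the limit leaves the size open) is none beyond the scatter. Compound 4 is estimated to give 100000 nM, within 40000 nM to 300000 nM, most probably again reported as a limit.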

Compound 4, half-maximal cytotoxic concentration: > 100000 nM
Compound 4 ended at the assay's limit; the forecaster's own chance of this, stated with the estimate: 85%; the middle value sits exactly at the limit.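

For the compounds shown here, no step from compound 1 to compound 4 can be read, because both stand only at a limit of the assay: (the limit of > 100000 nM in this assay, at which 4 of the 4 values shown sit). The compounds shown leave open what concentration of any of them these cells fail to tolerate, and whether oxan-4-yl in place of ethyl alters it.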